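A few compounds are considered here, and "the series" means these few. Any claim that something is new, unique, unknown or untested is made for them only; others in the source may bear on it.

Measured compounds:
- compound 1 `Cc1cccc(N2CCN(CCCNc3nc(NCc4ccco4)c4ccccc4n3)CC2)c1C`: 930 nM
- compound 2 `CN(C)CCNc1nc(NCc2ccco2)c2ccccc2n1`: "not determined" (no result reported)

For the measured compounds named here, compound 1 is the only compound of the series with a number in a functional assay on DU-145 cells (Homo sapiens) for cytotoxicity, read by MTT assay, with a stated time of 2 days; on this read-out lower numbers stand for stronger inhibition and higher numbers for weaker inhibition; in that assay compound 1 gives 930 nM. Going by the values given here, for compound 2 the assay reports "not determined" (no result reported), so no step between measured compounds can be drawn and compound 1 stands alone as the single reference point.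

Compound 3 `Clc1cccc(N2CCN(CCCNc3nc(NCc4ccco4)c4ccccc4n3)CC2)c1Cl` is the next entry to be measured. It differs from compound 1 by 2,3-dichlorophenyl in place of 2,3-dimethylphenyl on an amine nitrogen in a ring; the rest of the shared core is unchanged. Among the compounds with values here, with no measured pair to anchor the size of such a change, the expectation rests on compound 1 alone. The step from compound 1 to compound 3 is expected to stay within the usual scatter, with no direction that can be called beyond it, as a 1.2-fold lower number from compound 1 to compound 3 (0.07 log units; within the scatter). Compound 3 is therefore estimated at 800 nM in this assay, within a range of 300 nM to 2200 nM.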

Compound 3, half-maximal inhibitory concentration: 3710 nM
The estimate for compound 3 lay 4.6-fold (0.67 log units) below the measured number; measured number outside the range, above it.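

In this assay, the group on the amine nitrogen in a ring proves able to move the number: the change to 2,3-dichlorophenyl in place of 2,3-dimethylphenyl gives a 4.0-fold higher number from compound 1 to compound 3 (0.60 log units; beyond the scatter) and so favours 2,3-dimethylphenyl within this pair. The two groups have the same count of heavy atoms, the same six-membered aromatic ring of carbon only, no hydrogen-bond donors or acceptors and no net charge, so these counts do not separate them. No measurement at hand explains the step.

Going by these compounds, a single pair gives no trend, so it remains open whether the step follows from chlorine in place of methyl or holds only for this 2,3-substituted pair. Also open, on these data alone, is how an unsubstituted phenyl, a 2-methoxyphenyl or a pyridine ring on this nitrogen would compare, and what a longer chain to the shared core would do.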